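Swapping a Sulfonamide Substituent, With an Expected Outcome

The source may hold more compounds than are shown below. What is called first, only, known or untested is meant among the compounds shown, and "the series" means these compounds.

Of the compounds shown here, three have so far been tested in a functional assay on HEK293 cells (Homo sapiens) for cytotoxicity, read by XTT assay, with a stated time of 48 h; a lower number here means that less compound is needed, a higher number that more compound is needed for the effect. Compound 1 `C=CCN(CC=C)S(=O)(=O)c1ccc(NC(=O)c2ccc(C(C)(C)C)cc2)cc1` gives 9700 nM in this assay. Compound 2 `CC(=O)NS(=O)(=O)c1ccc(NC(=O)c2cc(-c3ccc(Cl)s3)nc3ccccc23)cc1` gives 75000 nM in this assay. Compound 3 `Cc1ccc(-c2nnc(Nc3cccc(O)c3)c3ccccc23)cc1S(=O)(=O)NC(C)(C)C` gives 10400 nM in this assay. Among these three numbers compound 3 stands second highest: its number and that of compound 1 lie within the scatter of each other, so the two cannot be told apart, while compound 2 needs a clearly higher amount than compound 3, a gap beyond the scatter.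

The next compound, compound 4 `CCOC(=O)CNS(=O)(=O)c1cc(-c2nnc(Nc3cccc(O)c3)c3ccccc23)ccc1C`, is compound 3 with a single alteration: (ethoxycarbonyl)methyl in place of tert-butyl on a sulfonamide nitrogen. The core and the amine-bearing part of compound 3 stay unchanged; only the group carried on the sulfonamide nitrogen is exchanged.

For the measured compounds named here, no pair of measured compounds shows this exact exchange, so no measured step can guide the expectation. With nothing in the measured set pointing one way or the other, the expectation for compound 4 in this assay is a step from compound 3 of a 1.2-fold higher number from compound 3 to compound 4 (0.06 log units; within the scatter), that is, no change beyond the scatter. Compound 4 is accordingly estimated at 12000 nM, within a range from 5000 nM to 30000 nM.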

Compound 4, half-maximal effective concentration: 13900 nM
The estimate for compound 4 lay 1.2-fold (0.06 log units) below the measured number; the range from low to high includes it.
By their numbers in this assay, from the lowest: compounds 1, 3 and 4 (each within the scatter of the next); then compound 2.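

The exchange of tert-butyl for (ethoxycarbonyl)methyl on a sulfonamide nitrogen gives a 1.3-fold higher number from compound 3 to compound 4 (0.13 log units; within the scatter) in this assay. The entering group carries oxygen atoms, a double bond outside aromatic rings and hydrogen-bond acceptors, none of which tert-butyl has, yet compound 3 and compound 4 cannot be told apart here, so this position tolerates at least this one change in make-up without a shift that can be read. No measurement at hand speaks to why the two compounds match.

Going by these compounds, whether the same holds for a group of a different kind on this nitrogen, such as a carboxylic acid, an amine or a longer chain, stays open, and so does the bare sulfonamide with only hydrogen there. A single step on a single core also cannot tell whether the same exchange would give a similarly small step on another core, or whether a cytotoxicity read-out on these cells would stay this flat over a wider range of groups.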